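Clearance notes: indole-to-chlorophenyl heteroaryl swap on the amide

A few compounds are considered here, and "the series" means these few. Any claim that something is new, unique, unknown or untested is made for them only; others in the source may bear on it.

Measured so far:
compound 1, `Cc1ccc2[nH]c(C(=O)N[C@H]3CN(S(=O)(=O)c4ccccc4)C[C@@H]3C(=O)N[C@H]3CCCN(C)C3)cc2c1`: 23 uL/min
compound 2, `Cc1ccc2[nH]c(C(=O)N[C@H]3CN(S(=O)(=O)c4ccccc4)C[C@@H]3C(=O)N[C@@H]3CCCNC3)cc2c1`: 9 uL/min

In an ADME assay on cells (Hepatocyte, Rattus norvegicus) for metabolic stability (on this read-out higher numbers stand for fast clearance and lower numbers for slow clearance), compound 1 gives 23 uL/min and stands highest of the two numbers; the nearest is compound 2 with 9 uL/min. Among the measured compounds shown here, the only step in the set, a 2.6-fold lower number from compound 1 to compound 2 (0.41 log units; beyond the scatter), exchanges piperidin-3-yl for 1-methylpiperidin-3-yl on an amide-type nitrogen and is modest.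

Compound 3, `CN1CCC[C@H](NC(=O)[C@H]2CN(S(=O)(=O)c3ccccc3)C[C@@H]2NC(=O)c2cc(-c3ccccc3Cl)on2)C1`, is not yet measured. Its change from compound 1 is a group of 12 heavy atoms (9 carbon, 1 nitrogen, 1 oxygen, 1 chlorine; one five-membered aromatic ring with 2 hetero atoms, one six-membered aromatic ring of carbon only) in place of a group of 10 heavy atoms (9 carbon, 1 nitrogen; one five-membered aromatic ring with 1 hetero atom, one six-membered aromatic ring of carbon only), on a carbonyl carbon: the 5-methyl-1H-indol-2-yl group leaves and a group with one five-membered aromatic ring with 2 hetero atoms and one six-membered aromatic ring of carbon only enters, on a carbonyl carbon whose other neighbour is an amide-type nitrogen. For the measured compounds named here, the 1-methylpiperidin-3-yl part is unchanged, so the step from compound 1 to compound 2 does not bear on this exchange; no measured step does. With nothing in the set to anchor the direction, the expectation for compound 3 in this assay is a step of about a 1.1-fold higher number from compound 1 to compound 3 (0.04 log units; within the scatter), within or near the scatter, and a wide range. Compound 3 is therefore estimated at 25 uL/min, between 9 uL/min and 70 uL/min.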

Compound 3, intrinsic clearance in a liver preparation (reported as CLH), per the amount of preparation that the assay uses: 31 uL/min
Compound 3: the middle estimate sits 1.2-fold (0.09 log units) below what was measured; the measured number falls inside the stated range.
By their numbers in this assay, from the lowest: compound 2; then compounds 1 and 3 (each within the scatter of the next).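

In this assay, replacing the 5-methyl-1H-indol-2-yl group on a carbonyl carbon whose other neighbour is an amide-type nitrogen gives a 1.3-fold higher number from compound 1 to compound 3 (0.13 log units; within the scatter), the first read at this position. The entering group has one five-membered aromatic ring with 2 hetero atoms and one six-membered aromatic ring of carbon only, and this full exchange leaves the two compounds indistinguishable on this read-out, whereas the change at the 1-methylpiperidin-3-yl part gave a 2.6-fold lower number from compound 1 to compound 2 (0.41 log units; beyond the scatter). No measurement at hand explains why this exchange stays within the scatter.

Still open, on these data alone, is whether the piperidin-3-yl exchange gives a step of similar size when it is carried out with the group of compound 3 on the carbonyl carbon. Among the compounds shown here, also open is how the read-out responds at this position to a plain phenyl, to a fluorine in place of the chlorine, or to a group carrying a carboxylic acid or an amine, since the single exchange here changes the ring system and the chlorine together and cannot separate their contributions.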